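Replacing the bromoindazole of compound 1 with a pyridine-fused ring

This account rests on a few compounds, and the source may have more. Where it says the series, first, only, none or still open, it means among the compounds named here.

Compound 1, `O=C(Nc1ccc(-n2ncc3c(Br)cccc32)cc1)Nc1ccc(Cl)c(C(F)(F)F)c1`: in a functional assay on MDA-MB-231 cells (Homo sapiens) for cytotoxicity, read by MTT assay, with a stated time of 72 h (on this read-out lower numbers stand for stronger inhibition and higher numbers for weaker inhibition), compound 1 gives 7700 nM.
Compound 2, `CNc1cccc2c1cnn2-c1ccc(NC(=O)Nc2ccc(Cl)c(C(F)(F)F)c2)cc1`: compound 2 gives 3600 nM.
Compound 3, `COc1cccc2c1cnn2-c1ccc(NC(=O)Nc2ccc(Cl)c(C(F)(F)F)c2)cc1`: compound 3 gives 1200 nM.

Of the three measured compounds, compound 1 has the highest number and so the weakest inhibition. Both changes made to it lower the number: a 2.1-fold lower number from compound 1 to compound 2 (0.33 log units; beyond the scatter) and a 6.4-fold lower number from compound 1 to compound 3 (0.81 log units; beyond the scatter), and between those two, a 3.0-fold lower number from compound 2 to compound 3 (0.48 log units; beyond the scatter).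

Compound 4, `O=C(Nc1ccc(-n2ncc3cnccc32)cc1)Nc1ccc(Cl)c(C(F)(F)F)c1`, differs from compound 1 by a group of 9 heavy atoms (6 carbon, 3 nitrogen; one five-membered aromatic ring with 2 hetero atoms, one six-membered aromatic ring with 1 hetero atom) in place of a group of 10 heavy atoms (7 carbon, 2 nitrogen, 1 bromine; one five-membered aromatic ring with 2 hetero atoms, one six-membered aromatic ring of carbon only), on an aromatic carbon. For the measured compounds named here, no measured step removes the bromo without putting a group in its place, and none adds a nitrogen into the six-membered ring, so the two measured steps from compound 1 bear only loosely on this change. They show that compound 1 is not the best that the shared core can do, and that replacing the bromo moved the number in one direction both times. For compound 4 a step of similar, modest size in the same direction is expected, a 2.2-fold lower number from compound 1 to compound 4 (0.34 log units; beyond the scatter). Compound 4 is therefore estimated at 3500 nM, with a range from 1200 nM to 10000 nM.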

Compound 4, half-maximal inhibitory concentration: 16000 nM
Beside the measured number, compound 4's estimate is 4.6-fold (0.66 log units) below it, outside the stated range (above it).
By their numbers in this assay, from the lowest: compound 3; then compound 2; then compound 1; then compound 4.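

In this assay, changing this part of compound 1 does not always lower the number: a 2.1-fold higher number from compound 1 to compound 4 (0.32 log units; beyond the scatter), whereas both earlier changes from compound 1 lowered it. This step removes the bromo and adds a nitrogen to the six-membered ring together, so it cannot show which of the two accounts for the rise. Nothing among the data shown gives a reason for this result.

Going by these compounds, it remains open whether the carbon-only six-membered ring with no bromo, or the nitrogen-containing ring carrying a methoxy, would separate the two parts of this change. On these data alone, it is also open how the nitrogen-containing ring would behave with a primary amine or a carboxylic acid on it.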